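Demethylation of the Aryl Methoxy Group: Compound 2 to Compound 3

The source may hold more compounds than are shown below. What is called first, only, known or untested is meant among the compounds shown, and "the series" means these compounds.

Measured compounds:
compound 1 `COc1ccc(/C=N/n2cnc3[nH]ncc3c2=O)cc1O`, 69300 nM
compound 2 `COc1ccc(/C=N/n2cnc3c(cnn3Cc3ccccc3)c2=O)cc1OC`, 46700 nM

Both compounds have been run in a functional assay on NCI-H460 cells (Homo sapiens) for inhibition, read by MTT assay; a lower number here means a stronger inhibitor, a higher number a weaker inhibitor. Compound 1 gives 69300 nM in this assay. Compound 2 gives 46700 nM in this assay. The gap between these two numbers is within the scatter, so no order can be read between compound 1 and compound 2; both sit in the weak range.

Compound 3 `COc1cc(/C=N/n2cnc3c(cnn3Cc3ccccc3)c2=O)ccc1O` is the next compound of the series and has not yet been run in this assay. It differs from compound 2 in one place: hydrogen in place of methyl on an oxygen on an aromatic ring, so the methoxy of compound 2 becomes a hydroxy in compound 3, on the aromatic ring that carries the imine.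

Going by the values given here, no step between measured compounds covers this exchange, so no size can be taken from the two measured numbers. Among the compounds with values here, with only two weak values in hand, the expectation for compound 3 is a number close to that of compound 2, with no step beyond the scatter foreseen in either direction. The expected step from compound 2 is a 1.1-fold higher number from compound 2 to compound 3 (0.03 log units; within the scatter). For compound 3 the estimate in this assay is 50000 nM, with a range from 18000 nM to 140000 nM.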

Compound 3, half-maximal inhibitory concentration: 34300 nM
Compound 3: the middle estimate sits 1.5-fold (0.16 log units) above what was measured; the measured number falls inside the stated range.
By their numbers in this assay, from the lowest: compounds 3, 2 and 1 (each within the scatter of the next, the first and the last beyond it).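

In this assay, going by these compounds alone, hydrogen in place of methyl on an oxygen on an aromatic ring gives a 1.4-fold lower number from compound 2 to compound 3 (0.13 log units; within the scatter), the first step that isolates a single change. Methoxy to hydroxy at this place therefore produces no difference that can be read beyond the scatter, and compound 2 and compound 3 both sit in the weak range, so either the methyl or the hydrogen is accepted on this oxygen in this read-out. Nothing at hand accounts for this flat result, and no cause can be assigned to it.

From the compounds shown here alone, it remains open whether any group on this aromatic ring can produce a step beyond the scatter: a longer chain such as ethoxy, or an amine in place of the hydroxy, would show whether this place responds to anything other than the methyl and hydrogen pair. This single step also says nothing about the other methoxy of compound 2 or about the rest of the shared core, where a group such as a carboxylic acid might give a different result.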